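Removing the Bromine from a Weak Cytotoxic Scaffold

The compounds below may be only part of what the source reports. "The series", "measured", "known", "first", "only" and "open" are said of these compounds alone.

Compound 1 `C=CCn1c(=O)/c(=C\c2cc(Br)ccc2F)[nH]c(=O)/c1=C\c1ccccc1OC` — 12900 nM
Compound 2 `COc1ccccc1/C=c1\c(=O)[nH]/c(=C/c2ccccc2Cl)c(=O)n1C` — "not determined" (no result reported)
Compound 3 `C=CCn1c(=O)/c(=C\c2cc(OC)c(OC)c(OC)c2)[nH]c(=O)/c1=C\c1cccc(Br)c1` — "not active" (no number reported)

Among the compounds with values here, in a functional assay on MOLT-4 cells (Homo sapiens) for cytotoxicity, read by CCK-8 assay, with a stated time of 72 h (on this read-out higher numbers stand for weaker inhibition and lower numbers for stronger inhibition), compound 1 gives 12900 nM, the only number in this set. Compound 2 is recorded as "not determined" (no result reported) and compound 3 as "not active" (no number reported), so compound 1 cannot be ranked against either and stands alone as a weak inhibitor. Compound 4 `C=CCn1c(=O)/c(=C\c2ccccc2F)[nH]c(=O)/c1=C\c1ccccc1OC` differs from compound 1 in one place: hydrogen in place of bromo on an aromatic carbon. Within the data shown here, no pair of measured compounds differs by a single change, so the size of this step has no precedent among them. With one weak number and nothing else to lean on, the step from compound 1 to compound 4 is expected to be small and toward weaker inhibition, a 1.6-fold higher number from compound 1 to compound 4 (0.19 log units; within the scatter). Compound 4 is therefore estimated at 20000 nM, with a range from 6000 nM to 60000 nM.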

Compound 4, half-maximal inhibitory concentration: 20000 nM
Compound 4: middle estimate and measured number agree at the digits printed; low and high end bracket the measured number.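

In this assay, within the data shown here, replacing bromo with hydrogen on the aromatic carbon gives a 1.6-fold higher number from compound 1 to compound 4 (0.19 log units; within the scatter), the first single-place comparison in this set. The 5-bromo-2-fluorophenyl and 2-fluorophenyl versions therefore cannot be told apart on this read-out, and the bromine is not needed to retain this weak level of inhibition. No measurement shown offers an explanation for this result.

From the compounds shown here alone, whether an amine or a carboxylic acid at this position would shift the number beyond the scatter remains open. So does the contribution of the fluoro group.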